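Toward compound 4: cytotoxicity limits in the series

The source may hold more compounds than are shown below. What is called first, only, known or untested is meant among the compounds shown, and "the series" means these compounds.

Compound 1 `CC(C)(C)NC(=O)COC(=O)c1ccc([N+](=O)[O-])o1` gives > 100000 nM in an ADME assay on HEK-293T cells (Homo sapiens) for cytotoxicity, read by MTT assay, with a stated time of 3 days (a higher number here means that more compound is tolerated, a lower number that less compound is tolerated), as its half-maximal cytotoxic concentration, and this is a limit of the assay, not a number. Compound 2 `CCC(C)(C)NC(=O)COC(=O)c1ccc([N+](=O)[O-])o1` gives > 100000 nM in this assay, which is again a limit. Compound 3 `CC(C)(C)N(CCCc1ccccc1)C(=O)COC(=O)c1ccc([N+](=O)[O-])o1` has no single number and is reported as "not active" (no number reported) in this assay, so its standing can only be stated in words.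

The change to compound 4 `CC(=O)Oc1ccccc1CN(C(=O)COC(=O)c1ccc([N+](=O)[O-])o1)C(C)(C)C` is 2-acetoxyphenyl in place of phenethyl on a saturated chain carbon bound to an amide-type nitrogen and places 2-acetoxyphenyl in place of phenethyl on a saturated chain carbon bound to an amide-type nitrogen. Among the measured compounds shown here, only one measured step bears on it, a step that the two limits leave unreadable from compound 1 to compound 2, and that step has no readable size. The nearest guide is the limit of > 100000 nM in this assay, at which 2 of the 3 values shown sit, which is also a limit and not a number. Resting on that step and that limit, no step beyond the scatter is expected in this assay in either direction, and the assay may well return only a limit again. For compound 4 the estimated half-maximal cytotoxic concentration is 100000 nM, with an expected range from 30000 nM to 200000 nM.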

Compound 4, half-maximal cytotoxic concentration: > 100000 nM
Compound 4 gave a limit, no number (the forecaster's own chance of this, stated with the estimate: 80%); the middle value lies on the limit itself.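

Compound 3 carries no number in this assay, so no new step can be read from compound 3 to compound 4. In this assay compound 4 gives > 100000 nM, a limit and not a number. The compounds shown leave open whether any of these changes shifts the half-maximal cytotoxic concentration at all, because the values stop at one limit: the limit of > 100000 nM in this assay, at which 3 of the 4 values shown sit.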